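The source may hold more compounds than are shown below. What is called first, only, known or untested is meant among the compounds shown, and "the series" means these compounds.

For the measured compounds named here, compound 2 `Nc1cc(N)c2nc(-c3ccccc3)c(Sc3ccc(Cl)c(Cl)c3)nc2c1` is the only member of this small set with a full number in a functional assay on LOX IMVI cells (Homo sapiens) for inhibition, read by sulforhodamine B assay, with a stated time of 48 h; a lower number here means a stronger inhibitor of growth, a higher number a weaker inhibitor of growth: compound 2 gives 24500 nM. Compound 1 `COc1ccc(Sc2nc3cc(N)cc(N)c3nc2-c2ccccc2)cc1`, which carries a 4-methoxyphenyl on the same sulfur, is reported only as a limit in this assay, where compound 1 shows < 100000 nM. The step that the limit leaves unreadable from compound 1 to compound 2 therefore cannot be read in size, since only a limit is reported for compound 1 (the limit of < 100000 nM in this assay, at which 1 of the 2 values shown sits). Compound 3 `Nc1cc(N)c2nc(-c3ccccc3)c(Sc3ccc(F)cc3)nc2c1` has not yet been measured in this assay. It differs from compound 2 in one place: 4-fluorophenyl in place of 3,4-dichlorophenyl on a sulfur. Going by the values given here, only one measured step touches the group on that sulfur, and it is the unreadable one from compound 1 to compound 2, so no measured step gives a size or a direction for the change to compound 3. Without such a guide, the estimated step is a 1.6-fold higher number from compound 2 to compound 3 (0.21 log units; within the scatter), toward weaker inhibition of growth. For compound 3 in this assay the estimate is 40000 nM, with a range from 12000 nM to 120000 nM.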

Compound 3, concentration for total growth inhibition: 40700 nM
Compound 3: middle estimate off by 1.0-fold (0.01 log units), on the low side; the measured number falls inside the stated range.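

At this position, the sulfur whose other neighbour is an aromatic carbon, this assay now offers a step that can be read in size: a 1.7-fold higher number from compound 2 to compound 3 (0.22 log units; within the scatter). With 4-fluorophenyl in place of 3,4-dichlorophenyl, compound 2 and compound 3 cannot be told apart in this growth read-out, so within this pair the two chlorines and the single fluorine on the phenyl ring make no difference that stands clear of the usual scatter. The steps that join compound 1 to compound 2 and to compound 3 still cannot be read, because compound 1 is reported only as a limit: the limit of < 100000 nM in this assay, at which 1 of the 3 values shown sits.

The compounds shown leave open whether a carboxylic acid or an amine on that phenyl ring, or a longer alkyl chain on the sulfur in place of the ring, would stand apart from compound 2 by more than the scatter. They also leave open how the 4-methoxyphenyl of compound 1 compares in size with the two halogen-bearing phenyl groups, and whether the same indifference would hold on a core carrying other groups.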